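A few compounds are considered here, and "the series" means these few. Any claim that something is new, unique, unknown or untested is made for them only; others in the source may bear on it.

Measured compounds:

compound 1 `CC(O)(CS(=O)(=O)c1ccc(Cl)cc1)c1nc(-c2ccc(Cl)cc2)no1` — in a functional assay on DU-145 cells (Homo sapiens) for cytotoxicity, read by MTT assay (on this read-out higher numbers stand for weaker inhibition and lower numbers for stronger inhibition), compound 1 gives > 100000 nM, a limit of the assay rather than a number.

compound 2 `CC(O)(CS(=O)(=O)c1ccc(F)cc1)c1nc(-c2ccc(F)c(Cl)c2)no1` — compound 2 gives > 100000 nM, again a limit of the assay.

compound 3 `CC(O)(CSc1ccc(Br)cc1)c1nc(-c2ccccc2)no1` — compound 3 gives > 100000 nM, also a limit of the assay.

Compound 2 therefore stands where every value shown stands: at the limit of > 100000 nM in this assay, at which 3 of the 3 values shown sit. No number separates it from compound 1 or compound 3; all three are limits, and nothing can be said of their order.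

The next compound, compound 4 `CC(O)(CS(=O)(=O)c1ccc(Cl)cc1)c1nc(-c2ccc(F)c(Cl)c2)no1`, differs from compound 2 in one place: chloro in place of fluoro on an aromatic carbon. Among the measured compounds shown here, no step between two measured compounds is available to size this change. With the three values at the limit, compound 4 is expected to show no step beyond the scatter, a number no higher from compound 2 to compound 4 (the limit leaves the size open). Compound 4 is estimated at 100000 nM, within 30000 nM to 300000 nM, most likely reported again as a limit.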

Compound 4, half-maximal inhibitory concentration: 35500 nM
The estimate for compound 4 lay 2.8-fold (0.45 log units) above the measured number; the measured number falls inside the stated range.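

In this assay, the change from 4-fluorophenyl to 4-chlorophenyl, on an aromatic carbon para to a large group, gives the first readable number, with an at least 2.8-fold lower number from compound 2 to compound 4 (0.44 log units; beyond the scatter). The other aryl group counts as well, with an at least 2.8-fold lower number from compound 1 to compound 4 (0.44 log units; beyond the scatter), so among these compounds a measurable number appears only where 4-chlorophenyl and 3-chloro-4-fluorophenyl occur together, and neither group alone in compound 1 or compound 2 gives one. Compound 4 alone stands apart from the rest of the set, whose other members all give a limit of the assay: the limit of > 100000 nM in this assay, at which 3 of the 4 values shown sit.

From the compounds shown here alone, it remains open whether bromo, methoxy or an amine at this place would lower the number further or return it to the limit. Going by these compounds, it is also open whether the hydroxyl group on the shared core contributes to the number seen for compound 4.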